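The source may hold more compounds than are shown below. What is called first, only, known or untested is meant among the compounds shown, and "the series" means these compounds.

- Compound 1 (`O=C(Nc1cccc([N+](=O)[O-])c1)c1cc(Cl)ccc1O`): 3530 nM
- Compound 2 (`O=C(Nc1cccc(F)c1)c1cc(Cl)ccc1O`): 3630 nM

In a toxicity assay on Vero C1008 cells (Chlorocebus sabaeus) for cytotoxicity, read by MTT assay, with a stated time of 48 h (a higher number here means that more compound is tolerated, a lower number that less compound is tolerated), compound 2 gives 3630 nM, which is within the usual scatter of compound 1. The next structure is compound 3 (`O=C(Nc1cccc(C(F)(F)F)c1)c1cc(Cl)ccc1O`), and the change is trifluoromethyl in place of fluoro on an aromatic carbon, with trifluoromethyl in place of fluoro on an aromatic carbon, meta to a large group. Among the measured compounds shown here, only one measured step bears on this: a 1.0-fold higher number from compound 1 to compound 2 (0.01 log units; within the scatter), with fluoro in place of nitro. That single step is a thin guide, and it points to no change beyond the scatter in this assay. The expected step is a 1.2-fold lower number from compound 2 to compound 3 (0.08 log units; within the scatter). Compound 3 is estimated at 3000 nM, with an expected range of 1400 nM to 6500 nM.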

Compound 3, half-maximal cytotoxic concentration: 5950 nM
Compound 3: the middle estimate sits 2.0-fold (0.30 log units) below what was measured; measured number inside the range.
By their numbers in this assay, from the lowest: compounds 1, 2 and 3 (each within the scatter of the next).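

Trifluoromethyl at this position, on an aromatic carbon and meta to a large group, stays within the scatter in this assay with a 1.6-fold higher number from compound 2 to compound 3 (0.21 log units; within the scatter) and with a 1.7-fold higher number from compound 1 to compound 3 (0.23 log units; within the scatter) as well. So the larger group, with four heavy atoms in place of the single one in fluoro, gives no step beyond the scatter, and the same holds for its swap with nitro. No measurement here accounts for this result. As far as these compounds go, it remains open whether an amine, a carboxylic acid or a longer chain at this position would give a step beyond the scatter.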